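The source may hold more compounds than are shown below. What is called first, only, known or untested is meant among the compounds shown, and "the series" means these compounds.

Measured so far, in a functional assay on HL-60 cells (Homo sapiens), read by calcium flux; on this read-out lower numbers stand for an effect already at smaller amounts and higher numbers for an effect only at larger amounts of compound:

Compound 1, `COc1ccc(Cc2cc(-c3cccs3)nn(CC(=O)Nc3ccc(Br)cc3)c2=O)cc1`, gives > 50000 nM, which is a limit of the assay rather than a number.
Compound 2, `Cc1cc(Cc2ccccc2)c(=O)n(CC(=O)Nc2ccc(Br)cc2)n1`, gives > 50000 nM, again only a limit.
Compound 3, `Cc1cc(Cc2ccccc2)c(=O)n(CC(=O)Nc2ccc(F)cc2)n1`, gives > 50000 nM, also a limit.

Compound 2 therefore cannot be placed on a scale: it shows only a limit, and the two other values shown are limits as well, all three sitting at the limit of > 50000 nM in this assay, at which 3 of the 3 values shown sit. Among the measured compounds shown here, the single step between measured compounds that differ in one place is a step that the two limits leave unreadable from compound 2 to compound 3, and with both ends at a limit its size cannot be read. Compound 4, `Cc1cc(N)c(=O)n(CC(=O)Nc2ccc(Br)cc2)n1`, differs from compound 2 by amino in place of benzyl on an aromatic carbon. For the measured compounds named here, no measured step involves this position or this kind of exchange, so nothing observed points in either direction. With every value shown at a limit, compound 4 is expected to show no readable effect either, its step being estimated as a number no higher from compound 2 to compound 4 (the limit leaves the size open). Compound 4 is thus estimated at 50000 nM in this assay, with a range from 10000 nM to 200000 nM, and most likely reported once more only as a limit.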

Compound 4, half-maximal effective concentration: > 50000 nM
Compound 4: a limit, no number; the forecaster's own chance of this, stated with the estimate: 85%; the middle value sits exactly at the limit.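

In this assay compound 4 gives > 50000 nM, again only a limit. Among the compounds shown here, compound 2 also stands at a limit, so no step from compound 2 to compound 4 can be read. The compounds shown leave open which structural change, if any, would give a measurable effect, because no value yet lies off this mark: the limit of > 50000 nM in this assay, at which 4 of the 4 values shown sit.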